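The compounds below may be only part of what the source reports. "The series", "measured", "known", "first", "only" and "open" are said of these compounds alone.

Measured compounds:
- compound 1 `CCCCc1ccc(CNS(=O)(=O)c2ccccc2)c(=O)n1Cc1ccc(-c2ccccc2-c2nn[nH]n2)cc1`: in a functional assay (aorta) for antagonist activity, with Oryctolagus cuniculus as the target (a higher number here means a weaker inhibitor, a lower number a stronger inhibitor), compound 1 gives 7 nM
- compound 2 `CCCCc1ccc(CN(Cc2ccccc2)S(=O)(=O)c2ccc(C)cc2)c(=O)n1Cc1ccc(-c2ccccc2-c2nn[nH]n2)cc1`: in this assay compound 2 gives 60 nM
- compound 3 `CCCCc1ccc(CN(Cc2ccccc2)S(=O)(=O)c2ccccc2)c(=O)n1Cc1ccc(-c2ccccc2-c2nn[nH]n2)cc1`: in this assay compound 3 gives 20 nM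

Compound 1 stands lowest of the three numbers in this assay; compound 3 is nearest to it, and compound 2 furthest. Compound 4 `CCCCc1ccc(CN(C(C)C)S(C)(=O)=O)c(=O)n1Cc1ccc(-c2ccccc2-c2nn[nH]n2)cc1` differs from compound 1 in one place: isopropyl(methylsulfonyl)amino in place of (phenylsulfonyl)amino on a saturated chain carbon bound to an aromatic carbon. Among the compounds with values here, two measured steps bear on this change. The step of a 2.9-fold higher number from compound 1 to compound 3 (0.46 log units; beyond the scatter) shows that placing a substituent on the sulfonamide nitrogen raised the number modestly. Within the data shown here, the step of a 3.0-fold lower number from compound 2 to compound 3 (0.48 log units; beyond the scatter) concerns a substituent on the aromatic ring of the sulfonyl group, and so touches the sulfonyl side only indirectly; no measured pair shows the exchange of the phenylsulfonyl for a methylsulfonyl. Since the nitrogen substitution in compound 4 parallels the step from compound 1 to compound 3, a modest rise in the number in this assay is expected, with added uncertainty from the unmeasured sulfonyl exchange. Compound 4 is therefore estimated at 40 nM, between 10 nM and 200 nM, which means an expected step of a 5.7-fold higher number from compound 1 to compound 4 (0.76 log units; beyond the scatter).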

Compound 4, half-maximal inhibitory concentration: 0.9 nM
The estimate for compound 4 lay 44-fold (1.65 log units) above the measured number; measured number below the stated range.
By their numbers in this assay, from the lowest: compound 4; then compound 1; then compound 3; then compound 2.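

In this assay the step of a 7.8-fold lower number from compound 1 to compound 4 (0.89 log units; beyond the scatter) comes with isopropyl(methylsulfonyl)amino in place of (phenylsulfonyl)amino, so at this saturated chain carbon a substituted sulfonamide nitrogen can go with a lower number. Within the data shown here, the only earlier step on that nitrogen, benzyl in place of hydrogen, gave a 2.9-fold higher number from compound 1 to compound 3 (0.46 log units; beyond the scatter) and went the other way, so losing the hydrogen on that nitrogen does not by itself set the direction of the change. Nothing given here accounts for the lower number.

This change alters the nitrogen substituent and the sulfonyl group together, and the compounds shown do not separate the two contributions. They also leave open how an ethyl or a cyclopropyl on the nitrogen, or an ethylsulfonyl in place of the methylsulfonyl, would behave.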